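Fluoro in Place of Hydrogen on Compound 1: Expected Growth Inhibition

A few compounds are considered here, and "the series" means these few. Any claim that something is new, unique, unknown or untested is made for them only; others in the source may bear on it.

Three compounds have been tested in a functional assay on A-431 cells (Homo sapiens) for cytotoxicity, read by MTT assay, with a stated time of 72 h, tested at 1 uM; on this read-out higher numbers stand for more inhibition of growth at the one concentration tested and lower numbers for less inhibition of growth:
compound 1 `N/C(=N\NC(=S)N1CCCCCC1)c1ccccn1` gives 18.8%;
compound 2 `Cc1ccnc(/C(N)=N/NC(=S)N2CCCCCC2)c1` gives 36.3%;
compound 3 `Cc1cccc(/C(N)=N/NC(=S)N2CCCCCC2)n1` gives 42.8%.

Compound 1 stands lowest of these three numbers. Compound 4 `N/C(=N\NC(=S)N1CCCCCC1)c1ccc(F)cn1` differs from it by one change: fluoro in place of hydrogen on an aromatic carbon.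

Among the compounds with values here, two measured steps bear on this, both placing a methyl on an aromatic carbon of the same core: a number 17.5 percentage points higher from compound 1 to compound 2 (beyond the scatter) and a number 24 percentage points higher from compound 1 to compound 3 (beyond the scatter). Fluoro is a different group, and no measured step shows its effect here, so the expectation rests only on the observation that a small group on this ring has so far raised the number. A modest rise in this assay, or no step beyond the scatter, is therefore expected for compound 4: a number 9.2 percentage points higher from compound 1 to compound 4 (within the scatter). Compound 4 is estimated at 28%, within 12% to 45%.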

Compound 4, percent growth inhibition at one concentration: 50.3%
For compound 4 the middle estimate is 22.3 percentage points below the measured one; the whole stated range lies below it.
By their numbers in this assay, from the lowest: compound 1; then compounds 2, 3 and 4 (each within the scatter of the next, the first and the last beyond it).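

In this assay, fluoro gives a number 31.5 percentage points higher from compound 1 to compound 4 (beyond the scatter), so this single fluorine atom, two atoms from the ring nitrogen and para to a large group, is enough to raise the number beyond the scatter. Until now, only methyl had shown such a rise on the core of compound 1, and this step is printed as large, where both methyl steps are modest. No measurement available here explains the size of this step.

On these data alone, whether chloro, methoxy or an amine at this same place would also raise the number remains open. So does how fluoro would behave elsewhere on the ring.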